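Pyridin-4-yl in place of 3-chlorophenyl on the amidine carbon

The compounds below may be only part of what the source reports. "The series", "measured", "known", "first", "only" and "open" are said of these compounds alone.

Measured compounds:
compound 1 `Fc1ccc(C2(c3ccc(F)cc3)CNC(c3cccc(Cl)c3)=N2)cc1` — 5.4 nM
compound 2 `N#Cc1cccc(C2=NC(c3ccc(F)cc3)(c3ccc(F)cc3)CN2)c1` — 2.7 nM
compound 3 `Fc1ccc(C2(c3ccc(F)cc3)CNC(c3cccnc3)=N2)cc1` — 7.2 nM

In an assay on LM cells for displacement of a labelled ligand from Neuropeptide Y receptor type 5 (Homo sapiens) (on this read-out lower numbers stand for stronger inhibition and higher numbers for weaker inhibition), compound 1 gives 5.4 nM, the second highest of the three numbers. Its nearest neighbour is compound 3, with a 1.3-fold higher number from compound 1 to compound 3 (0.12 log units; within the scatter), and its furthest is compound 2, with a 2.0-fold lower number from compound 1 to compound 2 (0.30 log units; within the scatter). Compound 4 `Fc1ccc(C2(c3ccc(F)cc3)CNC(c3ccncc3)=N2)cc1` has not yet been measured. It differs from compound 1 in one place: pyridin-4-yl in place of 3-chlorophenyl on a carbon with a double bond to nitrogen.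

Among the compounds with values here, the step that bears most on this change is the one from compound 1 to compound 3, in which pyridin-3-yl replaced 3-chlorophenyl on the same carbon with a double bond to nitrogen; that step was a 1.3-fold higher number from compound 1 to compound 3 (0.12 log units; within the scatter). The step from compound 2 to compound 3 was a 2.7-fold higher number from compound 2 to compound 3 (0.43 log units; beyond the scatter), so the pyridyl ring sat at the higher end of the three values. Within the data shown here, no measured step covers pyridin-4-yl itself. Compound 4 is therefore expected to show a number close to compound 1 or a little higher, roughly a 1.7-fold higher number from compound 1 to compound 4 (0.22 log units; within the scatter). The estimate for compound 4 in this assay is 9 nM, with a range from 3 nM to 30 nM.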

Compound 4, half-maximal inhibitory concentration: 160 nM
Beside the measured number, compound 4's estimate is 18-fold (1.25 log units) below it, outside the stated range (above it).
By their numbers in this assay, from the lowest: compounds 2, 1 and 3 (each within the scatter of the next, the first and the last beyond it); then compound 4.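

The earlier compounds shown here showed only modest differences among 3-chlorophenyl, 3-cyanophenyl and pyridin-3-yl on this carbon with a double bond to nitrogen, but in this assay pyridin-4-yl brought a 30-fold higher number from compound 1 to compound 4 (1.47 log units; beyond the scatter) and a 59-fold higher number from compound 2 to compound 4 (1.77 log units; beyond the scatter). The position therefore tolerates some aromatic rings and not others, and the comparison of the two pyridines gives a 22-fold higher number from compound 3 to compound 4 (1.35 log units; beyond the scatter), so a ring nitrogen as such is not the deciding feature: pyridin-3-yl stays within the scatter of 3-chlorophenyl, while pyridin-4-yl does not. Nothing available explains this loss.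

The compounds shown leave open whether the loss is confined to pyridin-4-yl or extends to groups such as 4-chlorophenyl or 4-cyanophenyl. They also leave open where pyridin-2-yl or an unsubstituted phenyl would fall on this read-out.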